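The source may report more compounds than this note shows. Statements on the series, on what has been measured and on what is new or still open speak of the compounds shown alone.

The study's read-out is an ADME assay on cells (Homo sapiens) for cytotoxicity, read by polymerase chain reaction, with a stated time of 3 days; a lower number here means that less compound is tolerated, a higher number that more compound is tolerated. Compound 1, with structure `CN(C)c1ccc2nc(-c3c(Cl)nc(N)nc3N[C@@H]3C[C@H](CO)[C@@H](O)[C@H]3O)sc2c1`, reaches only the assay's limit there, and its result of > 25000 nM is a limit rather than a number. Compound 2, `CN(C)c1ccc2sc(-c3c(Cl)nc(N)nc3N[C@@H]3C[C@H](CO)[C@@H](O)[C@H]3O)nc2c1`, gives 25000 nM in this assay. Compound 3, `CCOCCNc1nc(C)c(-c2nc3ccccc3s2)c(N[C@@H]2C[C@H](CO)[C@@H](O)[C@H]2O)n1`, gives 18000 nM in this assay, which is the lower of the two numbers shown; its nearest neighbour is compound 2, whose number is higher by an amount that lies within the usual scatter, so no order between compound 2 and compound 3 can be read from these two values. One of the three results is the limit (the limit of > 25000 nM in this assay, at which 1 of the 3 values shown sits).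

Compound 4, `Cc1nc(NCc2cccnc2)nc(N[C@@H]2C[C@H](CO)[C@@H](O)[C@H]2O)c1-c1nc2ccccc2s1`, has not yet been measured. Its structure differs from compound 3 by pyridin-3-yl in place of ethoxymethyl on a saturated chain carbon bound to a nitrogen on an aromatic ring. Since no step between measured compounds has been recorded for this kind of change, the expectation for compound 4 rests only on compound 3 and on the closeness of all three results shown. The author expects the step from compound 3 to compound 4 in this assay to be a 1.1-fold higher number from compound 3 to compound 4 (0.05 log units; within the scatter), that is, no change beyond the scatter. Compound 4 is therefore estimated to give 20000 nM in this assay, with an expected range from 8000 nM to 25000 nM.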

Compound 4, half-maximal cytotoxic concentration: 5000 nM
The estimate for compound 4 lay 4.0-fold (0.60 log units) above the measured number; the measured number lies below the stated range.
By their numbers in this assay, from the lowest: compound 4; then compounds 3 and 2 (each within the scatter of the next).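

In this assay, going by these compounds alone, the side chain gives the first step that can be read between two compounds differing in one place (a 3.6-fold lower number from compound 3 to compound 4 (0.56 log units; beyond the scatter)), with pyridin-3-yl in place of ethoxymethyl on a saturated chain carbon bound to a nitrogen on an aromatic ring. This position is therefore not indifferent in this assay, and the exchange of a ring-free group for a six-membered aromatic ring with one hetero atom goes with less compound being tolerated, although the counts of hydrogen-bond donors and acceptors in the two groups are the same. Nothing measured on these compounds accounts for the step.

The compounds shown leave open whether the lower number follows the ring nitrogen or the aromatic ring as such, a question on which a phenyl group in the place of pyridin-3-yl would bear. They also leave open how a longer chain carrying the same ring, or a simple amine at the end of the chain, would stand in this assay, and whether the step would carry over to the core of compound 1 or compound 2.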